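From phenyl to 1,1-dioxothian-4-yl: a metabolic stability step

This account rests on a few compounds, and the source may have more. Where it says the series, first, only, none or still open, it means among the compounds named here.

Among the compounds with values here, in an ADME assay (liver) for metabolic stability, with Liver microsome (Homo sapiens) as the target, read by LC-MS, using microsomes and NADPH, tested at 1 uM (a higher number here means that the compound lasts longer, a lower number that the compound disappears faster), compound 2 `CC(C)(C)c1cc(NC(=O)[C@@H]2CCCCN2C(=O)c2ccccc2)no1` gives 0.683 h, the higher of the two numbers measured so far; compound 1 `CC(C)(C)c1cc(NC(=O)[C@@H]2CCCCN2CC2CC2)no1` gives 0.15 h, and the step of a 4.6-fold higher number from compound 1 to compound 2 (0.66 log units; beyond the scatter) separates them. Compound 3 `CC(C)(C)c1cc(NC(=O)[C@@H]2CCCCN2C(=O)C2CCS(=O)(=O)CC2)no1` differs from compound 2 by 1,1-dioxothian-4-yl in place of phenyl on a carbonyl carbon. Within the data shown here, the only measured step alters the group on the ring nitrogen, not the group on the carbonyl carbon, so no measured step bears directly on this change. A small rise, possibly within the scatter, is expected for compound 3: a 1.3-fold higher number from compound 2 to compound 3 (0.12 log units; within the scatter). Compound 3 is therefore estimated at 0.9 h, within 0.35 h to 2.3 h.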

Compound 3, half-life: > 2 h
Compound 3 was reported as a limit; the forecaster's own chance of this, stated with the estimate: 5%; middle value at least 2.2-fold (0.34 log units) from the limit.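

Swapping phenyl for 1,1-dioxothian-4-yl on the carbonyl carbon gives a change beyond the scatter (an at least 2.9-fold higher number from compound 2 to compound 3 (0.46 log units; beyond the scatter)), so this place, which the earlier step did not touch, also moves the half-life in this assay. From the compounds shown here alone, for compound 3, the reading (> 2 h) is a limit and not a number, so the full size of the step stays unknown: the limit of > 2 h in this assay, at which 1 of the 3 values shown sits. The compounds shown leave open whether the rise goes with losing the aromatic ring or with gaining the sulfur and its two oxygens. A cyclohexyl group on the same carbonyl carbon would separate these two changes.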